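Adding propyl to the chain of compound 2

The source may report more compounds than this note shows. Statements on the series, on what has been measured and on what is new or still open speak of the compounds shown alone.

Measured so far in a functional assay on brain (Rattus norvegicus, strain Wistar) for inhibition (a higher number here means a weaker inhibitor, a lower number a stronger inhibitor), are two compounds:
compound 1 `Cc1ccc(-c2c(C)[nH]c(=O)n2C)cc1` gives 85300 nM as its half-maximal inhibitory concentration
compound 2 `CCCCCc1ccc(-c2c(C)[nH]c(=O)n2C)cc1` gives 5900 nM as its half-maximal inhibitory concentration

Of these two, compound 2 has the lower number and so is the stronger inhibitor, and the gap between them lies beyond the usual scatter. Compound 3 `CCCCCCCCc1ccc(-c2c(C)[nH]c(=O)n2C)cc1` keeps the shared core and differs from compound 2 only in its chain (propyl in place of hydrogen on a saturated chain carbon, five bonds along the chain from an aromatic carbon), which makes that chain longer.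

Among the compounds with values here, only one measured step bears on this change. It also lengthens the chain, and it is large: a 14-fold lower number from compound 1 to compound 2 (1.16 log units; beyond the scatter) in this comparison. Within the data shown here, one step cannot show a trend, and no measurement yet tells whether further lengthening keeps helping. Propyl is a smaller addition than butyl, so a further fall in the number is expected in this assay but probably a smaller one. The expected size is a 3.9-fold lower number from compound 2 to compound 3 (0.59 log units; beyond the scatter) in the same direction as before. Compound 3 is expected at 1500 nM with a range from 400 nM to 6000 nM in this estimate.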

Compound 3, half-maximal inhibitory concentration: 19400 nM
Compound 3: middle estimate off by 13-fold (1.11 log units), on the low side; the whole stated range lies below it.
By their numbers in this assay, from the lowest: compound 2; then compound 3; then compound 1.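

In this assay, lengthening the chain does not keep lowering the number: adding propyl reverses the direction of the earlier step, giving a 3.3-fold higher number from compound 2 to compound 3 (0.52 log units; beyond the scatter). The reversal does not cancel the whole gain, as the full change from the methyl-bearing parent to the longest chain still gives a 4.4-fold lower number from compound 1 to compound 3 (0.64 log units; beyond the scatter), a smaller gain than the one the shorter addition gave. This position therefore tolerates a long chain, but the response to length is not steady, and among these three compounds the best result comes from the middle length, while no measurement here offers an explanation for the reversal.

Going by these compounds, three chain lengths can only roughly locate the best one, so it remains open whether a hexyl chain would match or beat compound 2, and whether the number keeps rising with a still longer chain. It is also unknown whether the chain's length alone matters here, or whether a chain carrying an amine or a carboxylic acid would change the picture.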